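The source may hold more compounds than are shown below. What is called first, only, known or untested is meant among the compounds shown, and "the series" means these compounds.

Measured so far:
compound 1 `CCCCN(CC)c1cc(C)nc2c1NC(=O)CN2c1ccc(Br)cc1Br` gives 9.4%
compound 2 `CCCCN(CC)c1cc(C)nc2c1NC(=O)CN2c1ccc(C)cc1Br` gives 5.5%

Compound 2 stands lowest of the two numbers in an assay on HEK-293T cells for displacement of a labelled ligand from corticotropin-releasing factor receptor 2 (Homo sapiens), read by scintillation counting, with a stated time of 2 h, tested at 1 uM; on this read-out lower numbers stand for less inhibition and higher numbers for more inhibition at the one concentration tested (going by the name of the read-out); its nearest neighbour is compound 1, and the step of a number 3.9 percentage points lower from compound 1 to compound 2 (within the scatter) lies within the scatter, so no order between the two can be read from these values. Compound 3 `CCCCN(CC)c1cc(C)nc2c1NC(=O)CN2c1ccc(Br)cc1C` differs from compound 2 by 4-bromo-2-methylphenyl in place of 2-bromo-4-methylphenyl on a nitrogen on an aromatic ring in a ring. Going by the values given here, the only measured step that bears on this change is a number 3.9 percentage points lower from compound 1 to compound 2 (within the scatter), in which methyl in place of bromo on an aromatic carbon left the number within the scatter. With 4-bromo-2-methylphenyl in place of 2-bromo-4-methylphenyl, nothing in these two values points to a shift beyond the scatter. Compound 3 is therefore expected to give 7% in this assay, with a range from 0% to 16%. The step of a number 1.5 percentage points higher from compound 2 to compound 3 (within the scatter) that this estimate means is expected to stay within the scatter.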

Compound 3, a percentage reported as inhibition, at one concentration (the size of the read-out at that concentration, not a potency): 5.9%
The estimate for compound 3 lay 1.1 percentage points above the measured number; low and high end bracket the measured number.
By their numbers in this assay, from the lowest: compounds 2, 3 and 1 (each within the scatter of the next).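

Swapping the two groups on the phenyl ring, with 4-bromo-2-methylphenyl in place of 2-bromo-4-methylphenyl, gives a number a number 0.4 percentage points higher from compound 2 to compound 3 (within the scatter) in this assay, so this exchange of places on the ring, three ring bonds from the ring nitrogen, leaves the read-out within the scatter. Methyl in place of the other bromo group of compound 1 gives a number a number 3.5 percentage points lower from compound 1 to compound 3 (within the scatter), so methyl in place of bromo has now stayed within the scatter at both bromo-bearing carbons. No measurement at hand gives a reason for these numbers.

What the compounds shown leave open is whether any group on this phenyl ring can move the number beyond the scatter. As far as these compounds go, a methoxy group, a carboxylic acid or an amine there might do so, and the effect of a longer chain on the core's nitrogen also remains unknown.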